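A few compounds are considered here, and "the series" means these few. Any claim that something is new, unique, unknown or untested is made for them only; others in the source may bear on it.

Measured so far in a functional assay on MGC-803 cells (Homo sapiens) for cytotoxicity, read by MTT assay, with a stated time of 72 h (on this read-out lower numbers stand for stronger inhibition and higher numbers for weaker inhibition), are these compounds:

compound 1 `C=C1C(=O)[C@@]23C(=O)OC[C@]4(C(=O)CCC(C)(C)[C@H]4C=O)[C@@H]2CC[C@@H]1[C@H]3OC(=O)CC` gives 1780 nM
compound 2 `C=C1C(=O)[C@@]23C(=O)OC[C@]4(C(=O)CCC(C)(C)[C@H]4C=O)[C@@H]2CC[C@@H]1[C@H]3OC(=O)c1ccc(C)cc1` gives 2240 nM
compound 3 `C=C1C(=O)[C@@]23C(=O)OC[C@]4(C(=O)CCC(C)(C)[C@H]4C=O)[C@@H]2CC[C@@H]1[C@H]3OC(=O)c1ccc(OC)cc1` gives 1870 nM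

Compound 1 stands within the scatter of both other compounds, so these numbers set no order among the three. Compound 4 `C=C1C(=O)[C@@]23C(=O)OC[C@]4(C(=O)CCC(C)(C)[C@H]4C=O)[C@@H]2CC[C@@H]1[C@H]3OC(=O)c1ccc(Cl)cc1` has not yet been measured, and 4-chlorophenyl in place of ethyl on a carbonyl carbon describes how it differs from compound 1, with 4-chlorophenyl in place of ethyl on a carbonyl carbon. Within the data shown here, two measured steps bear on this change. Replacing the same ethyl gave a 1.3-fold higher number from compound 1 to compound 2 (0.10 log units; within the scatter) and a 1.1-fold higher number from compound 1 to compound 3 (0.02 log units; within the scatter) on the two aryl changes. Since neither step leaves the scatter, no step beyond the scatter is expected in this assay and no direction is favoured. The estimated step is a 1.1-fold higher number from compound 1 to compound 4 (0.05 log units; within the scatter) and it is expected to stay within the scatter. For compound 4 the expected value is 2000 nM with an estimated range from 1100 nM to 3500 nM on this measurement.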

Compound 4, half-maximal inhibitory concentration: 3120 nM
Beside the measured number, compound 4's estimate is 1.6-fold (0.19 log units) below it, and the stated range covers the measured number.
By their numbers in this assay, from the lowest: compounds 1, 3, 2 and 4 (each within the scatter of the next).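

In this assay, 4-chlorophenyl on this carbonyl carbon gives a 1.8-fold higher number from compound 1 to compound 4 (0.24 log units; within the scatter), and the two chloro changes give a 1.7-fold higher number from compound 3 to compound 4 (0.22 log units; within the scatter) and a 1.4-fold higher number from compound 2 to compound 4 (0.14 log units; within the scatter). Even with a third aryl group, these steps stay within the scatter, so chloro, methyl, methoxy and ethyl set no order at this position. Nothing shown here gives a reason for these numbers. The compounds leave open whether an amine or a carboxylic acid on the aromatic ring, or a longer chain in place of ethyl, would carry the number beyond the scatter.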